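Amide Variation on a Cyclopropane-Bearing Receptor Agonist Series

The source may hold more compounds than are shown below. What is called first, only, known or untested is meant among the compounds shown, and "the series" means these compounds.

Compound 1 `Cc1nc(-c2ccc(C(F)(F)F)cc2)sc1CNc1ccc(/C=C/C(=O)O)cc1`: 95%
Compound 2 `Cc1nc(-c2ccc(C(F)(F)F)cc2)sc1CNc1ccc(CCC(=O)NC(C)C)cc1`: 84%
Compound 3 `Cc1nc(-c2ccc(C(F)(F)F)cc2)sc1CNc1ccc([C@H]2C[C@@H]2C(=O)N(C)C)cc1`: 49%

In a functional assay on CHO cells for agonist activity at Free fatty acid receptor 1 (Homo sapiens), read by a luciferase reporter (a higher number here means a larger maximal response, a lower number a smaller maximal response), the three compounds are separated by clear steps: a number 11 percentage points lower from compound 1 to compound 2 (beyond the scatter), a number 46 percentage points lower from compound 1 to compound 3 (beyond the scatter) and a number 35 percentage points lower from compound 2 to compound 3 (beyond the scatter). Compound 3 therefore stands lowest of the three numbers.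

Compound 4 `Cc1nc(-c2ccc(C(F)(F)F)cc2)sc1CNc1ccc([C@H]2C[C@@H]2C(=O)NC2CCNC2)cc1` keeps the core of compound 3 and differs only at the amide: (pyrrolidin-3-yl)amino in place of dimethylamino on a carbonyl carbon. Going by the values given here, no measured step changes the carbonyl substituent alone; the step of a number 35 percentage points lower from compound 2 to compound 3 (beyond the scatter) alters both the chain and the amide nitrogen together and cannot be split. The measured steps thus give no firm direction for this change, and only a step within the usual scatter is expected, a number 1 percentage points higher from compound 3 to compound 4 (within the scatter). Compound 4 is estimated to reach 50%, between 30% and 75%.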

Compound 4, largest response reached (reported as percent of maximum), in percent of the reference or control that the assay uses: 52%
Beside the measured number, compound 4's estimate is 2 percentage points below it, within the range that was stated.
By their numbers in this assay, from the lowest: compounds 3 and 4 (each within the scatter of the next); then compound 2; then compound 1.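

In this assay, (pyrrolidin-3-yl)amino in place of dimethylamino gives a number 3 percentage points higher from compound 3 to compound 4 (within the scatter) and is the first step shown to change the carbonyl substituent alone; on the cyclopropyl amide, this position accepts the larger ring-bearing group without a change beyond the scatter. Going by these compounds alone, the amide swap leaves large gaps to the earlier compounds, with a number 32 percentage points lower from compound 2 to compound 4 (beyond the scatter) and a number 43 percentage points lower from compound 1 to compound 4 (beyond the scatter) still standing. Nothing available explains this outcome. The compounds shown leave open whether isopropylamino on this carbonyl carbon would behave the same way. They also leave open how a carboxylic acid on the cyclopropyl group would compare.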